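This account rests on a few compounds, and the source may have more. Where it says the series, first, only, none or still open, it means among the compounds named here.

Measured compounds:
- compound 1 `CCC(C)n1cnc2ncnc(N)c21`: > 30000 nM
- compound 2 `CC(C)Cn1cnc2c(N)ncnc21`: > 30000 nM

Compound 1 stands at a limit of the assay rather than a number in a functional assay on CHO cells for antagonist activity at adenosine receptor A2b (Homo sapiens); on this read-out higher numbers stand for weaker inhibition and lower numbers for stronger inhibition. Compound 2 likewise gives a limit only in this assay. Both values sit at the same limit (the limit of > 30000 nM in this assay, at which 2 of the 2 values shown sit), so the two compounds cannot be ordered against each other, and nothing beyond the scatter can be read from the pair.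

Compound 3 `CC(O)Cn1cnc2ncnc(N)c21` carries 2-hydroxypropyl in place of sec-butyl on an aromatic nitrogen. Within the data shown here, no measured step speaks to such a change, so the expected step from compound 1 to compound 3 in this assay, a step that the limit leaves unreadable from compound 1 to compound 3, is taken as none beyond the scatter, with the most likely outcome again a limit. The estimate for compound 3 is 40000 nM, with a range from 8000 nM to 200000 nM.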

Compound 3, inhibition constant: > 30000 nM
Compound 3: only a limit was reported; the forecaster's own chance of this, stated with the estimate: 80%; the middle value lies beyond the limit too.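

Compound 1 and compound 3 both sit at a limit, so no step can be read between them for 2-hydroxypropyl in place of sec-butyl: the limit of > 30000 nM in this assay, at which 3 of the 3 values shown sit. The compounds shown leave open whether any group on this aromatic nitrogen gives a readable value in this assay at all.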